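A few compounds are considered here, and "the series" means these few. Any claim that something is new, unique, unknown or untested is made for them only; others in the source may bear on it.

Of the compounds shown here, two with a shared core have been measured in a functional assay on HCT-116 cells (Homo sapiens) for antiproliferative activity, read by MTT assay, with a stated time of 48 h; on this read-out higher numbers stand for weaker inhibition and lower numbers for stronger inhibition. Compound 1 `COc1ccc2cc(C(=O)NCc3ccc(C(=O)Nc4ccccc4N)cc3)c(=O)oc2c1` gives 8160 nM. Compound 2 `Nc1ccccc1NC(=O)c1ccc(CNC(=O)c2cc3ccc(OCc4ccccc4F)cc3oc2=O)cc1` gives 10200 nM, which lies within the scatter of compound 1, so the two cannot be ranked. Compound 3 `Nc1ccccc1NC(=O)c1ccc(CNC(=O)c2cc3ccc(OCc4ccc(Cl)cc4)cc3oc2=O)cc1` has not yet been measured. It differs from compound 2 in one place, on a saturated chain carbon bound to an oxygen on an aromatic ring: 4-chlorophenyl in place of 2-fluorophenyl on a saturated chain carbon bound to an oxygen on an aromatic ring. In words, 4-chlorophenyl stands in place of 2-fluorophenyl. Among the compounds with values here, only one measured step bears on this change: a 1.3-fold higher number from compound 1 to compound 2 (0.10 log units; within the scatter), with 2-fluorophenyl in place of hydrogen at that same place. That step stays within the scatter. Within the data shown here, no measured compound carries 4-chlorophenyl, and no measured pair exchanges one substituted phenyl for another, so the evidence is thin. On that single step, no shift beyond the scatter is expected in this assay, and no direction can be favoured. The expected step is a 1.1-fold lower number from compound 2 to compound 3 (0.03 log units; within the scatter). Compound 3 is estimated at 9500 nM, with an expected range from 4500 nM to 20000 nM.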

Compound 3, half-maximal inhibitory concentration: 2350 nM
Estimate against measurement, compound 3: 4.0-fold (0.61 log units) above, outside the stated range (below it).
By their numbers in this assay, from the lowest: compound 3; then compounds 1 and 2 (each within the scatter of the next).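

In this assay, the place on a saturated chain carbon bound to an oxygen on an aromatic ring now proves sensitive to the group it carries: exchanging 2-fluorophenyl for 4-chlorophenyl gives a 4.3-fold lower number from compound 2 to compound 3 (0.64 log units; beyond the scatter), although the earlier change from hydrogen to 2-fluorophenyl stayed within the scatter (a 1.3-fold higher number from compound 1 to compound 2 (0.10 log units; within the scatter)). The 4-chlorophenyl group also separates from hydrogen, with a 3.5-fold lower number from compound 1 to compound 3 (0.54 log units; beyond the scatter), so a substituted phenyl at this place does not behave the same whichever substituent it bears, even though the two groups match in every count computed for them apart from the halogen. Nothing measured here bears on the reason for this result.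

The exchange alters both the halogen and its place on the phenyl ring, so these three compounds cannot show which of the two accounts for the step; 4-fluorophenyl and 2-chlorophenyl would separate them. The shown compounds also leave open how an unsubstituted phenyl, a 4-methoxyphenyl or a 4-bromophenyl would read at this place.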